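The source may report more compounds than this note shows. Statements on the series, on what has been measured and on what is new or still open speak of the compounds shown alone.

Compound 1 `CCc1ccc(C(=O)NC[C@H]2c3[nH]c4ccccc4c3C[C@H]3[C@H]4c5[nH]c6ccccc6c5C[C@@H]([C@H](C#N)N23)N4C)cc1`: 570 nM in a functional assay on HepG2 cells (Homo sapiens) for cytotoxicity, read by MTT assay, with a stated time of 72 h; on this read-out lower numbers stand for stronger inhibition and higher numbers for weaker inhibition.
Compound 2 `CN1[C@@H]2c3[nH]c4ccccc4c3C[C@H]1[C@H](C#N)N1[C@@H](CNC(=O)c3cccc4c3CCCC4)c3[nH]c4ccccc4c3C[C@@H]21`: 540 nM in this assay.
Compound 3 `CN1[C@@H]2c3[nH]c4ccccc4c3C[C@H]1[C@H](C#N)N1[C@@H](CNC(=O)c3ccc4ccccc4c3)c3[nH]c4ccccc4c3C[C@@H]21`: 1210 nM in this assay.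

Compound 3 stands at the highest number of the three. The step of a 2.1-fold higher number from compound 1 to compound 3 (0.33 log units; beyond the scatter) and the step of a 2.2-fold higher number from compound 2 to compound 3 (0.35 log units; beyond the scatter) both rise modestly, while the step of a 1.1-fold lower number from compound 1 to compound 2 (0.02 log units; within the scatter) stays within the scatter. Compound 4 `CN1[C@@H]2c3[nH]c4ccccc4c3C[C@H]1[C@H](C#N)N1[C@@H](CNC(=O)c3cc4ccccc4o3)c3[nH]c4ccccc4c3C[C@@H]21` carries the change (1-benzofuran-2-yl in place of naphthalen-2-yl on a carbonyl carbon). Going by the values given here, no measured compound carries this group, so the only guide is that the other two groups on that carbonyl carbon gave lower numbers than naphthalen-2-yl. A modest downward step, or none beyond the scatter, is therefore expected in this assay. Compound 4 is estimated at 850 nM, with a range from 400 nM to 1800 nM. This expectation means a step of a 1.4-fold lower number from compound 3 to compound 4 (0.15 log units; within the scatter).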

Compound 4, half-maximal inhibitory concentration: 280 nM
For compound 4 the middle estimate is 3.0-fold (0.48 log units) above the measured one; measured number outside the range, below it.
By their numbers in this assay, from the lowest: compounds 4, 2 and 1 (each within the scatter of the next, the first and the last beyond it); then compound 3.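

In this assay, going by these compounds alone, the group on this carbonyl carbon moves the number further than the earlier compounds showed: 1-benzofuran-2-yl in place of naphthalen-2-yl gives a 4.3-fold lower number from compound 3 to compound 4 (0.64 log units; beyond the scatter). Against the other two groups the steps are smaller, with a 2.0-fold lower number from compound 1 to compound 4 (0.31 log units; beyond the scatter) and a 1.9-fold lower number from compound 2 to compound 4 (0.29 log units; within the scatter). No measurement here says what lies behind these steps. Going by these compounds, whether the ring oxygen of 1-benzofuran-2-yl matters remains open, and a 1-benzothiophen-2-yl group, with sulfur in its place, would test that on the same carbonyl carbon.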